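One Fluorine Added to a Compound at the Assay Limit

The compounds below may be only part of what the source reports. "The series", "measured", "known", "first", "only" and "open" are said of these compounds alone.

Compound 1 `CCOC1=C(/C(C)=N/OCC(=O)Nc2ccccc2)N(C)S(=O)(=O)c2ccccc21`: in a functional assay on THP-1 cells (Homo sapiens) for inhibition, read by ELISA, with stated times of 2 h and 48 h (on this read-out lower numbers stand for stronger inhibition and higher numbers for weaker inhibition), compound 1 gives > 20000 nM, which is a limit of the assay and not a number.
Compound 2 `CCOC1=C(/C(C)=N/OCC(=O)Nc2cccc(F)c2)N(C)S(=O)(=O)c2ccccc21`: in this assay compound 2 gives > 20000 nM, also a limit.
Compound 3 `C/C(=N\OCC(=O)Nc1ccccc1)C1=C(O)c2ccccc2S(=O)(=O)N1C`: in this assay compound 3 gives > 20000 nM, again a limit.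

Compound 3 thus stands where every value shown stands, at the limit of > 20000 nM in this assay, at which 3 of the 3 values shown sit; no number is known for it, only this limit. Compound 4 `C/C(=N\OCC(=O)Nc1cccc(F)c1)C1=C(O)c2ccccc2S(=O)(=O)N1C` differs from compound 3 by fluoro in place of hydrogen on an aromatic carbon. For the measured compounds named here, two measured steps bear on this change. The same change made on compound 1 gives a step that the two limits leave unreadable from compound 1 to compound 2. The other step, a step that the two limits leave unreadable from compound 1 to compound 3, shows that removing the ethyl did not bring compound 3 to a readable number either. Neither step tells how large this change is, so no direction can be read from them. With all three values at the limit, compound 4 is expected to stay there too, and the step that the limit leaves unreadable from compound 3 to compound 4 is an estimate that carries little weight. Compound 4 is therefore estimated at 30000 nM, within 15000 nM to 100000 nM, and most probably reported once more only as a limit.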

Compound 4, half-maximal inhibitory concentration: > 20000 nM
Compound 4 ended at the assay's limit; the forecaster's own chance of this, stated with the estimate: 85%; the middle value is on the limit's open side.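

The new steps to compound 4, from compound 3 and from compound 2, cannot be read, because both ends of each step are limits and not numbers: the limit of > 20000 nM in this assay, at which 4 of the 4 values shown sit.

The compounds shown leave open how large either change, fluoro in place of hydrogen or hydrogen in place of ethyl, is, and in which direction it acts.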